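A few compounds are considered here, and "the series" means these few. Any claim that something is new, unique, unknown or untested is made for them only; others in the source may bear on it.

Measured compounds:
- compound 1, `C=CCn1ncc2c(C)nc(CC)n2c1=O` — in a functional assay for inhibition, with Homo sapiens as the target (a lower number here means a stronger inhibitor, a higher number a weaker inhibitor), compound 1 gives only a limit, > 48000 nM
- compound 2, `CCc1nc(C)c2cnn(CC)c(=O)n12` — in this assay compound 2 gives 75600 nM

Among the compounds with values here, compound 1 stands only at a limit of this assay, not at a number; compound 2 is the one measured value in the set. The step from compound 1 to compound 2, a step that the limit leaves unreadable from compound 1 to compound 2, is methyl in place of vinyl on a saturated chain carbon bound to an aromatic nitrogen, and its size cannot be read because of the limit of > 48000 nM in this assay, at which 1 of the 2 values shown sits.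

Compound 3, `C=CCn1ncc2c(C)nc(Cc3ccccc3)n2c1=O`, is the next member. It differs from compound 1 as phenyl in place of methyl on a saturated chain carbon bound to an aromatic carbon, the same difference cut one bond further out reading ethyl to benzyl. Within the data shown here, no measured step touches that position; the only step recorded, that from compound 1 to compound 2, concerns the chain on the aromatic nitrogen and is itself unreadable. Nothing therefore points to a direction, and the expected step is an at least 1.2-fold lower number from compound 1 to compound 3 (0.07 log units; that floor lies within the scatter), none beyond the scatter. Compound 3 is accordingly estimated at 40000 nM, with a range from 8000 nM to 200000 nM, and a substantial chance that this assay again returns only a limit.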

Compound 3, half-maximal inhibitory concentration: > 48000 nM
Compound 3 was reported as a limit; the forecaster's own chance of this, stated with the estimate: 55%; middle value at least 1.2-fold (0.07 log units) from the limit.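

In this assay compound 3 gives only a limit (> 48000 nM). Compound 1 also stands at a limit, so no step can be read between the two: the limit of > 48000 nM in this assay, at which 2 of the 3 values shown sit.

The compounds shown leave open whether phenyl in place of methyl on a saturated chain carbon bound to an aromatic carbon changes inhibition at all, and in which direction.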